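This account rests on a few compounds, and the source may have more. Where it says the series, first, only, none or still open, it means among the compounds named here.

Of the compounds shown here, three with a shared core have been measured in a functional assay on A549 cells (Homo sapiens) for cytotoxicity, read by MTT assay, with a stated time of 72 h; a higher number here means a weaker inhibitor, a lower number a stronger inhibitor. Compound 1 `COc1cc(Nc2nc3ccccc3nc2S(=O)(=O)c2ccc(C)cc2)cc(OC)c1` gives 8060 nM. Compound 2 `COc1ccc(S(=O)(=O)c2nc3ccccc3nc2Nc2cc(OC)cc(OC)c2)cc1` gives 12700 nM, the highest of the three numbers. Compound 3 `COc1ccc(S(=O)(=O)c2nc3ccccc3nc2Nc2cc(OC)c(OC)c(OC)c2)cc1` gives 5170 nM, the lowest of the three.

Two steps connect them. The step of a 1.6-fold higher number from compound 1 to compound 2 (0.20 log units; within the scatter) exchanges one group on the ring that carries the sulfonyl, and it stays within the scatter. The step of a 2.5-fold lower number from compound 2 to compound 3 (0.39 log units; beyond the scatter) adds a group on the other, methoxy-bearing ring, and it is a modest change beyond the scatter.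

Compound 4 `COc1cc(Nc2nc3ccccc3nc2S(=O)(=O)c2ccc(F)cc2)cc(OC)c1` is not yet measured. It differs from compound 2 in one place: fluoro in place of methoxy on an aromatic carbon. This change sits on the same aromatic carbon that was altered in the step from compound 1 to compound 2, so that step is the one that bears on it, and it was within the scatter. The step from compound 2 to compound 3 concerns a different ring and says little here.

For the measured compounds named here, on that basis, the step of a 1.6-fold lower number from compound 2 to compound 4 (0.20 log units; within the scatter) is expected to stay small, with a slight lean toward a lower number because the only comparable exchange, a 1.6-fold higher number from compound 1 to compound 2 (0.20 log units; within the scatter), moved little. Compound 4 is therefore estimated at 8000 nM, in a range from 3500 nM to 18000 nM.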

Compound 4, half-maximal inhibitory concentration: 5450 nM
Compound 4: middle estimate off by 1.5-fold (0.17 log units), on the high side; the range from low to high includes it.
By their numbers in this assay, from the lowest: compounds 3, 4, 1 and 2 (each within the scatter of the next, the first and the last beyond it).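

In this assay the exchange of 4-methoxyphenyl for 4-fluorophenyl gives a 2.3-fold lower number from compound 2 to compound 4 (0.37 log units; beyond the scatter) and so lies beyond the scatter, which shows that this aromatic carbon can register a change of group, though only modestly; the earlier exchange of methyl for methoxy at the same carbon could not show this, as it stayed within the scatter. The other new comparison at this carbon, a 1.5-fold lower number from compound 1 to compound 4 (0.17 log units; within the scatter) within the same assay, does not separate fluoro from methyl, so among these three groups only methoxy and fluoro stand apart, while methyl lies within the scatter of both. Nothing available here explains the difference between methoxy and fluoro at this carbon.

The compounds shown leave open how an amine, a carboxylic acid or a longer chain on this carbon would read in this assay, since only three small groups have been compared there. They also leave open whether fluoro at this carbon combined with the added methoxy of compound 3 on the other ring would lower the number further, or whether the two changes would not add up.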